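Swapping the aryl group of compound 3

This account rests on a few compounds, and the source may have more. Where it says the series, first, only, none or still open, it means among the compounds named here.

In a functional assay on SK-OV-3 cells (Homo sapiens) for inhibition, read by CCK-8 assay, with a stated time of 70 h (on this read-out lower numbers stand for stronger inhibition and higher numbers for weaker inhibition), compound 1 (`Clc1ccc(COc2ccc(OCCOCCNC3CCCCC3)cc2)cc1`) gives 2650 nM, compound 3 (`Nc1ccccc1COc1ccc(OCCOCCNC2CCCC2)cc1`) gives 14000 nM and compound 2 (`OCCOCCOCCOc1ccc(OCc2ccccc2)cc1`) gives 59400 nM. Compound 3 thus holds the second highest of the three numbers, and its gaps to both other compounds lie beyond the usual scatter of repeated measurements.

Compound 4 (`COC(=O)c1cccc(COc2ccc(OCCOCCNC3CCCC3)cc2)c1`) has not yet been measured. The change from compound 3 is 3-(methoxycarbonyl)phenyl in place of 2-aminophenyl on a saturated chain carbon bound to an oxygen on an aromatic ring. Nothing else in the structure differs.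

Going by the values given here, no measured pair isolates a single change, so the data offer no direct guide to this swap. A small move towards a lower number in this assay is expected, and it may well stay within the scatter. Among the compounds with values here, the only support is that compound 1 at 2650 nM shows that lower numbers occur in this small set, which is weak evidence for the direction. The expected change is a 1.8-fold lower number from compound 3 to compound 4 (0.24 log units; within the scatter). The estimate for compound 4 is 8000 nM, with an expected range of 3000 nM to 20000 nM.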

Compound 4, half-maximal inhibitory concentration: 45500 nM
Compound 4: middle estimate off by 5.7-fold (0.75 log units), on the low side, and the stated range ends below it.
By their numbers in this assay, from the lowest: compound 1; then compound 3; then compounds 4 and 2 (each within the scatter of the next).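

In this assay, going by these compounds alone, 3-(methoxycarbonyl)phenyl in place of 2-aminophenyl on a saturated chain carbon bound to an oxygen on an aromatic ring gives a 3.3-fold higher number from compound 3 to compound 4 (0.51 log units; beyond the scatter), the first single-change comparison, so the read-out at this position depends on the aryl group, and the swap moves it towards weaker inhibition. Within the data shown here, the step is modest, and it bundles several changes: the substituent differs in identity and in its printed ring position, the heavy-atom count rises, and the hydrogen-bond donor of the leaving group has no counterpart in the entering one. Nothing available assigns the step to any one of these changes.

The compounds shown leave open whether the substituent itself or its ring position carries the step, and 3-aminophenyl and 2-(methoxycarbonyl)phenyl on the same carbon would separate the two. They also leave open whether the methyl ester matters as such, which a carboxylic acid or a primary amide at the same ring position would test.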